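GPR119 carbamate series: forecast for the ethylcyclopropyl carbamate

The compounds below may be only part of what the source reports. "The series", "measured", "known", "first", "only" and "open" are said of these compounds alone.

Measured so far:
compound 1 `Cc1nc(S(C)(=O)=O)ccc1Oc1ncnc(OC2CCN(C(=O)O[C@@H](C)CF)CC2)c1F`, 186 nM
compound 2 `Cc1nc(S(C)(=O)=O)ccc1Oc1ncnc(OC2CCN(C(=O)O[C@H](C)C(F)(F)F)CC2)c1F`, 9.2 nM

Going by the values given here, in a functional assay on isolated protein for inhibition of Glucose-dependent insulinotropic receptor (Homo sapiens), read by HTRF and cAMP accumulation (a higher number here means that more compound is needed for the effect, a lower number that less compound is needed), compound 2 gives 9.2 nM, the lowest of the two numbers so far; its nearest neighbour is compound 1 at 186 nM. Among the compounds with values here, the one step on the oxygen next to the carbonyl, a 20-fold lower number from compound 1 to compound 2 (1.31 log units; beyond the scatter), shows that this group moves the read-out strongly. Compound 3 `CCC1(OC(=O)N2CCC(Oc3ncnc(Oc4ccc(S(C)(=O)=O)nc4C)c3F)CC2)CC1` changes the same position: 1-ethylcyclopropyl in place of 1-(trifluoromethyl)ethyl on an oxygen next to a carbonyl group. Within the data shown here, no measured step covers a group of carbon only here, so the direction rests on the size of that single step alone. A moderate loss is expected, a 3.3-fold higher number from compound 2 to compound 3 (0.51 log units; beyond the scatter), giving for compound 3 an estimated 30 nM with a range from 6 nM to 150 nM.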

Compound 3, half-maximal effective concentration: 22 nM
Beside the measured number, compound 3's estimate is 1.4-fold (0.13 log units) above it, within the range that was stated.
By their numbers in this assay, from the lowest: compound 2; then compound 3; then compound 1.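

In this assay, this position on the oxygen next to a carbonyl group does not depend on fluorine, as 1-ethylcyclopropyl, of carbon only, costs little against 1-(trifluoromethyl)ethyl, with a 2.4-fold higher number from compound 2 to compound 3 (0.38 log units; beyond the scatter), yet it still gains much over 1-(fluoromethyl)ethyl, with an 8.5-fold lower number from compound 1 to compound 3 (0.93 log units; beyond the scatter). Compound 3 therefore goes against any reading of the order as a simple rise with fluorine count. No measurement on hand explains these differences.

As far as these compounds go, it remains open whether the three-membered ring or the ethyl carries the result, which 1-methylcyclopropyl or a longer chain would test. An amine or a carboxylic acid on this group is also untested territory in the compounds shown.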